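A few compounds are considered here, and "the series" means these few. Any claim that something is new, unique, unknown or untested is made for them only; others in the source may bear on it.

Measured in a functional assay on MCF7 cells (Homo sapiens) for antiproliferative activity, read by MTT assay, with a stated time of 48 h; on this read-out higher numbers stand for weaker inhibition and lower numbers for stronger inhibition:
- compound 1 `Oc1ccc2ccccc2c1C(Nc1nc2ccccc2s1)c1cn(-c2ccccc2)nc1-c1ccccc1`: 48900 nM
- compound 2 `COc1cccc(-c2nn(-c3ccccc3)cc2C(Nc2nc3ccccc3s2)c2c(O)ccc3ccccc23)c1`: 16900 nM
- compound 3 `COc1ccc(-c2nn(-c3ccccc3)cc2C(Nc2nc3ccccc3s2)c2c(O)ccc3ccccc23)cc1`: 17500 nM

Compound 3 sits level with compound 2 and clearly under compound 1. The next compound is compound 4 `Oc1ccc2ccccc2c1C(Nc1nc2ccccc2s1)c1cn(-c2ccccc2)nc1-c1cccc(Cl)c1`, with the change 3-chlorophenyl in place of 4-methoxyphenyl on an aromatic carbon. Methoxy in place of hydrogen gave modest steps, a 2.9-fold lower number from compound 1 to compound 2 (0.46 log units; beyond the scatter) and a 2.8-fold lower number from compound 1 to compound 3 (0.45 log units; beyond the scatter). Shifting the methoxy gave a 1.0-fold higher number from compound 2 to compound 3 (0.02 log units; within the scatter). Among the compounds with values here, no chlorine-bearing compound has been measured, so these steps are only a loose guide. In this assay, no step beyond the scatter is expected, in either direction, and a modest one would not surprise. The expected change is a 1.1-fold higher number from compound 3 to compound 4 (0.06 log units; within the scatter). The estimate for compound 4 is 20000 nM, with an expected range of 8000 nM to 50000 nM.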

Compound 4, half-maximal inhibitory concentration: 20700 nM
Estimate against measurement, compound 4: 1.0-fold (0.01 log units) below; the range from low to high includes it.
By their numbers in this assay, from the lowest: compounds 2, 3 and 4 (each within the scatter of the next); then compound 1.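

In this assay the 3-chlorophenyl compound stays level with both methoxy compounds, with a 1.2-fold higher number from compound 3 to compound 4 (0.07 log units; within the scatter) and a 1.2-fold higher number from compound 2 to compound 4 (0.09 log units; within the scatter) as the steps, so exchanging methoxy for chloro at this position gives no readable difference. The gain over the unsubstituted phenyl also holds without a hydrogen-bond acceptor on the ring, as a 2.4-fold lower number from compound 1 to compound 4 (0.37 log units; beyond the scatter) is modest, like the methoxy steps. No evidence at hand explains this shared level. Still open, as far as these compounds go, is whether an amine or a carboxylic acid on this phenyl group would hold the same level, and whether 4-chlorophenyl would match 3-chlorophenyl.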